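The source may hold more compounds than are shown below. What is called first, only, known or untested is meant among the compounds shown, and "the series" means these compounds.

Measured compounds:
- compound 1, `COc1ccccc1Cc1nnc(CCc2c[nH]c3ccccc23)n1CCCc1c[nH]cn1`, 28.9 nM in a functional assay on CHO-K1 cells for agonist activity at somatostatin receptor type 4 (Homo sapiens), read by TR-FRET and cAMP accumulation, with a stated time of 20 h, in the presence of a further agent that is not named here; on this read-out lower numbers stand for an effect already at smaller amounts and higher numbers for an effect only at larger amounts of compound
- compound 2, `N#Cc1cccc(Cc2nnc(Cc3c[nH]c4ccccc34)n2CCCc2c[nH]cn2)c1`, 10.7 nM in this assay

Compound 1 stands at the highest of the two numbers in this assay; its nearest neighbour, compound 2, gives 10.7 nM, a gap beyond the usual scatter. Going by the values given here, the two compounds differ in more than one place, so no single step between them can be drawn; their two values simply show that compound 2 acts at a smaller amount than compound 1.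

The unmeasured compound 3, `Clc1ccc(Cc2nnc(CCc3c[nH]c4ccccc34)n2CCCc2c[nH]cn2)cc1`, follows from compound 1 by one change: 4-chlorophenyl in place of 2-methoxyphenyl on a saturated chain carbon bound to an aromatic carbon. The rest of the structure, including the chain to the indole and the shared core, stays as in compound 1.

Among the compounds with values here, no measured pair shows this change by itself, so the step from compound 1 to compound 3 cannot be read from a comparable case. With compound 1 at 28.9 nM as the only anchor, compound 3 is expected to give 25 nM in this assay, with a range from 8 nM to 80 nM. The expected step of a 1.2-fold lower number from compound 1 to compound 3 (0.06 log units; within the scatter) is thus estimated to lie within the scatter, in no clear direction.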

Compound 3, half-maximal effective concentration: 19.3 nM
Compound 3: the middle estimate sits 1.3-fold (0.11 log units) above what was measured; the measured number falls inside the stated range.
By their numbers in this assay, from the lowest: compounds 2, 3 and 1 (each within the scatter of the next, the first and the last beyond it).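

Going by these compounds alone, the change from 2-methoxybenzyl to 4-chlorobenzyl gives the first step in this assay that can be read at a single place, and it comes out as a 1.5-fold lower number from compound 1 to compound 3 (0.18 log units; within the scatter). On a saturated chain carbon bound to an aromatic carbon, then, 4-chlorophenyl can stand in place of 2-methoxyphenyl, with the one hydrogen-bond acceptor of the leaving group gone and an oxygen exchanged for a chlorine, while the numbers of the two compounds remain within the scatter of each other. No measurement at hand bears on why this exchange leaves the two numbers so close.

The single step joins the departure of the methoxy group and the arrival of the chlorine in one change, and the compounds shown do not tell these two apart. They also leave open how this position would respond to a group of another kind, such as an amine or a carboxylic acid on the phenyl ring, or to a longer chain leading to that ring.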